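Working notes: from compound 2 to compound 4

The source may report more compounds than this note shows. Statements on the series, on what has been measured and on what is new or still open speak of the compounds shown alone.

The series was run in a functional assay on SGC-7901 cells (Homo sapiens) for antiproliferative activity, read by sulforhodamine B assay, with a stated time of 72 h; a higher number here means a weaker inhibitor, a lower number a stronger inhibitor. Compound 1 `CN(C)C(=S)N/N=C/c1cc2cccnc2s1` gives 21400 nM there, and compound 3 `CN(C)C(=S)N/N=C/c1nc2ccccc2s1` gives 830 nM in this assay. Compound 2 `Fc1ccccc1NC(=S)N/N=C/c1ccc2ccccc2n1` returns only a limit in this assay, > 100000 nM, and no number. This places compound 2 at the limit of > 100000 nM in this assay, at which 1 of the 3 values shown sits, so its standing relative to compound 1 and compound 3 cannot be read from the numbers shown; it is the one compound of the three without a measured value.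

Compound 4 `Fc1ccc(NC(=S)N/N=C/c2ccc3ccccc3n2)cc1` has not yet been measured. It differs from compound 2 in a single place: 4-fluorophenyl in place of 2-fluorophenyl on an amide-type nitrogen. Among the measured compounds shown here, no measured step between compounds differing in one place exists in this set, so the size of the change on going to a 4-fluorophenyl group cannot be anchored. Given the limit for compound 2, the step in this assay is expected to be none beyond the scatter, with a real chance that compound 4 also returns only a limit. Compound 4 is therefore estimated at 100000 nM, within a range from 30000 nM to 300000 nM. The step this estimate implies, a number no higher from compound 2 to compound 4 (the limit leaves the size open), is expected to be small.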

Compound 4, half-maximal inhibitory concentration: 32300 nM
Beside the measured number, compound 4's estimate is 3.1-fold (0.49 log units) above it, and the stated range covers the measured number.
By their numbers in this assay, from the lowest: compound 3; then compounds 1 and 4 (each within the scatter of the next). At a limit, above all of these: compound 2.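

Exchanging 2-fluorophenyl for 4-fluorophenyl on the amide-type nitrogen gives, in this assay, an at least 3.0-fold lower number from compound 2 to compound 4 (0.49 log units; beyond the scatter). Among the compounds shown here, this is the first one-place comparison, and it shows that this place on the nitrogen responds to which fluorophenyl group it carries, even though the atoms stay the same. The true size of the step remains open because compound 2 is recorded only as a limit: the limit of > 100000 nM in this assay, at which 1 of the 4 values shown sits.

The compounds shown leave open how an unsubstituted phenyl, a 3-fluorophenyl, a 4-chlorophenyl or a 4-methoxyphenyl group would read on this nitrogen. Going by these compounds, whether the same exchange would carry over to the core of compound 3 also stays open.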